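The source may report more compounds than this note shows. Statements on the series, on what has been measured and on what is new or still open speak of the compounds shown alone.

Three compounds have so far been measured in an ADME assay on J774 cells (Mus musculus) for cytotoxicity, read by resazurin assay, with a stated time of 72 h; on this read-out lower numbers stand for higher toxicity in this test and higher numbers for lower toxicity in this test:

Compound 1, `C/C1=C/C[C@@H]2[C@H](CC2(C)C)[C@@](O)(CO)CC[C@@H]1O`, gives 194000 nM.
Compound 2, `CC(=O)OC[C@@]1(O)CC[C@H]2O[C@@]2(C)CC[C@@H]2[C@@H]1CC2(C)C`, gives 273000 nM.
Compound 3, `C/C=C(/C)C(=O)OCC(O)(COC(=O)/C(C)=C\C)[C@H](OC(=O)/C(C)=C\C)[C@@H](COC(C)=O)OC(C)=O`, gives 198000 nM.

All three numbers sit close together. Compound 3 stands within the usual scatter of both compound 1 and compound 2 in this assay, so on this read-out the three compounds cannot be told apart, and none of them can be called more or less toxic than another.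

The next compound follows from compound 3 by a single change. Compound 4, `C/C=C(/C)C(=O)OC[C@@H](OC(C)=O)[C@@H](OC(=O)/C(C)=C\C)C(O)(COC(=O)/C(C)=C\C)COC(=O)/C(C)=C\C`, differs from compound 3 as follows: 1-methylprop-1-en-1-yl in place of methyl on a carbonyl carbon. The rest of the molecule, with its several ester groups around the shared core, is kept as it is.

Among the measured compounds shown here, no measured pair in this set shows what such a change does in this assay, so there is no step to lean on. Given that compound 1, compound 2 and compound 3 all fall within the scatter of one another despite quite different structures, the expected step from compound 3 to compound 4 is a 1.1-fold lower number from compound 3 to compound 4 (0.05 log units; within the scatter), that is, no change beyond the scatter. Compound 4 is therefore estimated at 175000 nM, with a range from 80000 nM to 380000 nM.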

Compound 4, half-maximal cytotoxic concentration: 206000 nM
Compound 4: middle estimate off by 1.2-fold (0.07 log units), on the low side; measured number inside the range.
By their numbers in this assay, from the lowest: compounds 1, 3, 4 and 2 (each within the scatter of the next).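

In this assay, among the compounds shown here, the change of methyl to 1-methylprop-1-en-1-yl on a carbonyl carbon gives a 1.0-fold higher number from compound 3 to compound 4 (0.02 log units; within the scatter), the first direct reading of a single change in this set, and it shows that this acetoxy group can become ((1-methylprop-1-en-1-yl)carbonyl)oxy with no difference this test can tell. The earlier compounds shown here could only be set side by side across quite different structures, whereas compound 3 and compound 4 share everything except this one group, so here the larger group itself is what is being tested. Nothing measured here offers an explanation for this result.

From the compounds shown here alone, this single step speaks for one group at one place, so it remains open whether an amine, a carboxylic acid or a longer chain on the same carbonyl carbon would also stay within the scatter. Going by these compounds, it also remains open whether the same change would read alike on the acetoxymethyl group of compound 2, which is built on a different core.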